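The compounds below may be only part of what the source reports. "The series", "measured", "known", "first", "only" and "open" are said of these compounds alone.

Among the measured compounds shown here, compound 2 `COC(CCn1cnc2c(NCc3ccc(C(=O)Nc4ccccc4N)cc3)nc(Cl)nc21)OC` gives 51.2% in a functional assay on NCI-H460 cells (Homo sapiens) for antiproliferative activity, read by CCK-8 assay, with a stated time of 72 h, tested at 8 uM (a lower number here means a weaker effect, a higher number a stronger effect of the compound at the concentration tested), the higher of the two numbers known here; compound 1 `Nc1ccccc1NC(=O)/C=C/c1ccc(Cn2cnc3c(Nc4cccc(Cl)c4)nc(Cl)nc32)cc1` gives 29.4% in this assay, and the gap between the two lies beyond the usual scatter. Compound 3 `CCCn1cnc2c(NCc3ccc(C(=O)Nc4ccccc4N)cc3)nc(Cl)nc21` has not yet been measured. It differs from compound 2 in one place: methyl in place of dimethoxymethyl on a saturated chain carbon, two bonds along the chain from an aromatic nitrogen. For the measured compounds named here, no measured pair shows this same change, so nothing directly tells its size or direction. The step of a number 6.2 percentage points lower from compound 2 to compound 3 (within the scatter) is expected to be small and slightly downward, within the scatter. Compound 3 is estimated at 45%, in a range from 25% to 65%.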

Compound 3, a percentage reported as inhibition, at one concentration (the size of the read-out at that concentration, not a potency): 39.2%
Estimate against measurement, compound 3: 5.8 percentage points above; measured number inside the range.
By their numbers in this assay, from the lowest: compounds 1 and 3 (each within the scatter of the next); then compound 2.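

In this assay, among the compounds shown here, methyl in place of dimethoxymethyl on this saturated chain carbon gives a number 12 percentage points lower from compound 2 to compound 3 (beyond the scatter) and is the first comparison here that changes only one place. It shows that the group at the end of this chain affects the read-out, and that dimethoxymethyl gives the higher number of these two groups. Nothing available here explains this step. Whether the two oxygen atoms or the extra carbon atoms account for the difference stays open. A plain butyl chain, or a chain ending in an alcohol, an amine or a carboxylic acid, could help separate these possibilities.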